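Replacing propyl with a pyrazolyl ring on the amide nitrogen

This account rests on a few compounds, and the source may have more. Where it says the series, first, only, none or still open, it means among the compounds named here.

Of the compounds shown here, three have been measured so far. Compound 3 `CCCN(Cc1cccs1)C(=O)COc1ccc(C)cc1` stands second highest of the three in an assay on HEK293 cells for agonist activity at transient receptor potential cation channel subfamily M member 8 (Homo sapiens), read by fluorescence and calcium flux, with a stated time of 15 min (a lower number here means that less compound is needed, a higher number that more compound is needed for the effect), where compound 3 gives 40 nM. Compound 1 `CCN(Cc1cccs1)C(=O)COc1ccc(C)cc1` gives 8 nM in this assay, and compound 2 `Cc1ccc(OCC(=O)N(Cc2cccs2)C2COC2)cc1` gives 23000 nM. The step of a 5.0-fold higher number from compound 1 to compound 3 (0.70 log units; beyond the scatter) is modest, whereas a 2900-fold higher number from compound 1 to compound 2 (3.46 log units; beyond the scatter) is large, and a 580-fold lower number from compound 2 to compound 3 (2.76 log units; beyond the scatter) is correspondingly large in the other direction.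

Compound 4 `Cc1ccc(OCC(=O)N(Cc2cccs2)c2ccn[nH]2)cc1` differs from compound 3 in one place: 1H-pyrazol-5-yl in place of propyl on an amide-type nitrogen. Among the measured compounds shown here, the step that bears most on this change is the one between compound 3 and compound 2, where the propyl on the amide-type nitrogen gave way to a ring with a hetero atom, and a 580-fold lower number from compound 2 to compound 3 (2.76 log units; beyond the scatter) shows how far apart those two compounds lie. Compound 4 again places a ring on that nitrogen, here an aromatic one carrying both a donor and an acceptor, so a large rise in this assay is expected, of the order of a 250-fold higher number from compound 3 to compound 4 (2.40 log units; beyond the scatter). Compound 4 is therefore estimated at 10000 nM, with a range from 1500 nM to 60000 nM, and there is a fair chance that only a limit will be reported.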

Compound 4, half-maximal effective concentration: 0.2 nM
The estimate for compound 4 lay 50000-fold (4.70 log units) above the measured number; the whole stated range lies above it.
By their numbers in this assay, from the lowest: compound 4; then compound 1; then compound 3; then compound 2.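

In this assay, a ring on the amide-type nitrogen does not by itself push the number up: 1H-pyrazol-5-yl gives a 200-fold lower number from compound 3 to compound 4 (2.30 log units; beyond the scatter) and also improves on the ethyl of the best earlier compound, with a 40-fold lower number from compound 1 to compound 4 (1.60 log units; beyond the scatter), so compound 4 has the lowest number of the four. The two ring-bearing compounds lie at opposite ends of the series, with a 120000-fold lower number from compound 2 to compound 4 (5.06 log units; beyond the scatter), which shows that at this position the identity of the ring decides the outcome, and that the presence of a ring with hetero atoms does not. Nothing available here accounts for this reversal or for the size of these steps.

The compounds shown leave open whether a phenyl ring on the amide-type nitrogen would give a number close to that of compound 4, or whether the nitrogens of the pyrazolyl ring are needed. As far as these compounds go, it also remains open whether a 1-methylpyrazol-5-yl group, with a methyl in place of the ring's nitrogen-bound hydrogen, or an imidazolyl ring would keep the low number.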